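Pyridin-2-yl swap at the low end of the series

The source may hold more compounds than are shown below. What is called first, only, known or untested is meant among the compounds shown, and "the series" means these compounds.

For the measured compounds named here, in an ADME assay on cells (Hepatocyte, Rattus norvegicus) for metabolic stability (a lower number here means that the compound disappears faster, a higher number that the compound lasts longer), compound 1 `O=C(C1CCN(c2ncccn2)CC1)N1N=CC[C@H]1c1ccccc1` gives 0.137 h, the lowest of the three numbers so far. Compound 3 `N#Cc1nccc(N2CCC(C(=O)N3N=CC[C@H]3c3cc(F)cc(F)c3)CC2)n1` gives 0.917 h and compound 2 `N#Cc1ccc(N2CCC(C(=O)N3N=CC[C@H]3c3cc(F)cc(F)c3)CC2)nn1` gives 2.08 h, both beyond the scatter from compound 1. Compound 4 `O=C(C1CCN(c2ccccn2)CC1)N1N=CC[C@H]1c1ccccc1` carries one change from compound 1: pyridin-2-yl in place of pyrimidin-2-yl on an amine nitrogen in a ring. Going by the values given here, the one measured swap of an aromatic ring at this place is modest, a 2.3-fold lower number from compound 2 to compound 3 (0.36 log units; beyond the scatter), and those rings differ from the present pair. It sets no direction here, so no step beyond the scatter is expected in this assay. The expected step is a 1.2-fold lower number from compound 1 to compound 4 (0.10 log units; within the scatter). For compound 4 the estimate is 0.11 h, with an expected range of 0.05 h to 0.25 h.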

Compound 4, half-life: 0.0633 h
For compound 4 the middle estimate is 1.7-fold (0.24 log units) above the measured one, and the stated range covers the measured number.
By their numbers in this assay, from the lowest: compound 4; then compound 1; then compound 3; then compound 2.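

Pyridin-2-yl in place of pyrimidin-2-yl on the amine nitrogen gives a 2.2-fold lower number from compound 1 to compound 4 (0.34 log units; beyond the scatter) in this assay, so a ring swap at this place moves the number beyond the scatter even at the low end of the series. For the compounds shown here, this modest step is the first measured at this place on the core of compound 1, and compound 4 now stands lowest of the four. Nothing measured here bears on the cause of this step.

Still open, from the compounds shown here alone, is whether the step carries over to the core of compound 2. Also open, going by these compounds, is how a methoxy group on the pyridin-2-yl, or a saturated tetrahydropyranyl ring at this place, would read.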